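A few compounds are considered here, and "the series" means these few. Any claim that something is new, unique, unknown or untested is made for them only; others in the source may bear on it.

Compound 1 `COc1ccc(/C=C\C(=O)O)c(OCc2cn(-c3cccc(C#N)c3)nn2)c1CC=C(C)C` and compound 2 `COc1ccc(/C=C\C(=O)O)c(OCc2cn(-c3ccc(CO)cc3)nn2)c1CC=C(C)C` share one core and differ only in the group on an aromatic nitrogen. In a functional assay on COLO 205 cells (Homo sapiens) for cytotoxicity, read by MTT assay, with a stated time of 24 h (on this read-out higher numbers stand for weaker inhibition and lower numbers for stronger inhibition), compound 1 gives 26800 nM, and compound 2 gives 19300 nM; the step of a 1.4-fold lower number from compound 1 to compound 2 (0.14 log units; within the scatter) leaves the pair within the scatter, so compound 2 stands alongside compound 1 rather than apart from it. Compound 3 `COc1ccc(/C=C\C(=O)O)c(OCc2cn(-c3ccc(C#N)cc3)nn2)c1CC=C(C)C` carries cyano in place of hydroxymethyl on an aromatic carbon. Among the measured compounds shown here, the only measured step also alters the group on that aromatic nitrogen and is small, so no shift in this assay beyond the scatter is expected: a 1.2-fold higher number from compound 2 to compound 3 (0.08 log units; within the scatter). Compound 3 is estimated at 23000 nM, between 11000 nM and 48000 nM.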

Compound 3, half-maximal inhibitory concentration: 32000 nM
Compound 3: the middle estimate sits 1.4-fold (0.14 log units) below what was measured; the range from low to high includes it.
By their numbers in this assay, from the lowest: compounds 2, 1 and 3 (each within the scatter of the next).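

In this assay, cyano in place of hydroxymethyl on the aromatic carbon para to a large group gives a 1.7-fold higher number from compound 2 to compound 3 (0.22 log units; within the scatter), so exchanging these two groups at this place does not separate the compounds. Moving the nitrile, 4-cyanophenyl in place of 3-cyanophenyl, gives a 1.2-fold higher number from compound 1 to compound 3 (0.08 log units; within the scatter), so that change does not separate them either. Nothing available explains these readings. From the compounds shown here alone, whether an amine or a longer chain on this aromatic ring would shift the number beyond the scatter remains open.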